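The source may hold more compounds than are shown below. What is called first, only, known or untested is meant among the compounds shown, and "the series" means these compounds.

Two thymidine analogues carrying a disulfide on the sugar have been measured so far. Compound 1, `Cc1cn([C@H]2C[C@H](SSC(Cl)(Cl)Cl)[C@@H](CO)O2)c(=O)[nH]c1=O`, gives 13000 nM in an assay on isolated protein for inhibition of thymidine kinase, cytosolic (Homo sapiens); a lower number here means a stronger inhibitor, a higher number a weaker inhibitor. Compound 2, `Cc1cn([C@H]2C[C@H](SSCCO)[C@@H](CO)O2)c(=O)[nH]c1=O`, gives 18000 nM. The step of a 1.4-fold higher number from compound 1 to compound 2 (0.14 log units; within the scatter) is the only one recorded, and it does not leave the scatter. On the two numbers shown, compound 2 has the highest number, with compound 1 its nearest neighbour at a distance that is also within the scatter. Compound 3, `Cc1cn([C@H]2C[C@H](SSCCN)[C@@H](CO)O2)c(=O)[nH]c1=O`, is the next compound to be taken into this assay. It differs from compound 2 in a single place: amino in place of hydroxy on a saturated chain carbon, two bonds along the chain from a sulfur. For the measured compounds named here, no measured step bears on this exchange of hydroxy for amino; the one measured step, between compound 1 and compound 2, concerns a different group on the chain and was within the scatter. With nothing in the measured pair pointing either way, the expected step of no change at the digits printed from compound 2 to compound 3 (within the scatter) is none beyond the scatter. Compound 3 is therefore estimated at 18000 nM, within a range from 7000 nM to 45000 nM.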

Compound 3, half-maximal inhibitory concentration: 10000 nM
Compound 3: middle estimate off by 1.8-fold (0.26 log units), on the high side; low and high end bracket the measured number.
By their numbers in this assay, from the lowest: compounds 3, 1 and 2 (each within the scatter of the next).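

In this assay, amino in place of hydroxy on a saturated chain carbon, two bonds along the chain from a sulfur, gives a 1.8-fold lower number from compound 2 to compound 3 (0.26 log units; within the scatter) and stays inside the scatter, so compound 2 and compound 3 cannot be told apart at this position. Replacing trichloromethyl on a sulfur with 2-aminoethyl gives a 1.3-fold lower number from compound 1 to compound 3 (0.11 log units; within the scatter), and this too stays inside the scatter, so trichloromethyl, 2-hydroxyethyl and 2-aminoethyl on that sulfur all read alike in this assay on the three compounds shown. Nothing measured here offers an explanation for these numbers.

As far as these compounds go, all three compounds keep the disulfide and the shared core, so it remains open whether any group on that sulfur can shift the number beyond the scatter, and whether the disulfide itself matters. A carboxylic acid or a dimethylamino group in place of amino, a longer chain on the sulfur, or a thioether in place of the disulfide would each address a question that these three compounds cannot settle.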